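The compounds below may be only part of what the source reports. "The series", "measured", "known", "first", "only" and "open" are said of these compounds alone.

Measured compounds in a functional assay on BXPC-3 cells (Homo sapiens) for inhibition, read by MTT assay, with a stated time of 7 days; a higher number here means a weaker inhibitor, a lower number a stronger inhibitor:
Compound 1, `CCN(CC)S(=O)(=O)c1ccc(S(=O)(=O)N2CCC[C@@H](C(=O)N3CCC(C(F)(F)F)CC3)C2)cc1`, gives 370 nM.
Compound 2, `CCN(CC)S(=O)(=O)c1ccc(S(=O)(=O)N2CCC[C@@H](C(=O)N[C@H]3CC[C@@H](OC)CC3)C2)cc1`, gives 2150 nM.

Compound 2 stands at the weaker end of these two numbers, its nearest neighbour being compound 1, and the step between them, a 5.8-fold higher number from compound 1 to compound 2 (0.76 log units; beyond the scatter), lies beyond the scatter. Compound 3, `CCN(CC)S(=O)(=O)c1ccc(S(=O)(=O)N2CCC[C@@H](C(=O)N3CC[C@@H](OC)C3)C2)cc1`, is made from compound 2 by the change (3-methoxypyrrolidin-1-yl in place of (4-methoxycyclohexyl)amino on a carbonyl carbon). For the measured compounds named here, only that one measured step bears on it: it shows that trading a cyclic amine on the carbonyl carbon for the (4-methoxycyclohexyl)amino group cost potency. Compound 3 returns to a cyclic amine at that position, though a different one from compound 1, so a partial recovery is expected, smaller than the full step, and its estimated step is a 2.4-fold lower number from compound 2 to compound 3 (0.38 log units; beyond the scatter). Compound 3 is thus estimated at 900 nM, within the range 350 nM to 2500 nM.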

Compound 3, half-maximal inhibitory concentration: 11500 nM
For compound 3 the middle estimate is 13-fold (1.11 log units) below the measured one, and the stated range ends below it.
By their numbers in this assay, from the lowest: compound 1; then compound 2; then compound 3.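

In this assay, the step of a 5.3-fold higher number from compound 2 to compound 3 (0.73 log units; beyond the scatter) shows that a cyclic amine on this carbonyl carbon does not by itself outperform (4-methoxycyclohexyl)amino, a reading that the earlier pair alone had left possible. The step of a 31-fold higher number from compound 1 to compound 3 (1.49 log units; beyond the scatter) shows that two cyclic amines at this place can also lie far apart, so the amine class alone does not set the value among these compounds. Nothing measured here accounts for these losses.

Going by these compounds, compound 1 and compound 3 differ in both ring and substituent, so the share of each in the step remains open. A 4-methoxypiperidin-1-yl or a 3-(trifluoromethyl)pyrrolidin-1-yl group on the same carbonyl carbon would separate the two.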